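The source may report more compounds than this note shows. Statements on the series, on what has been measured and on what is new or still open speak of the compounds shown alone.

Values so far in a functional assay on HeLa cells (Homo sapiens) for antiproliferative activity, read by MTT assay, with a stated time of 48 h; on this read-out higher numbers stand for weaker inhibition and lower numbers for stronger inhibition
- compound 1 `O=C(OCc1ccccc1)c1ccc2[nH]c(-c3cn(-c4ccccc4)nc3-c3ccccc3)nc2c1` gives 21300 nM
- compound 2 `COc1ccc(-c2nn(-c3ccccc3)cc2-c2nc3cc(Cl)ccc3[nH]2)cc1` gives 1290 nM
- compound 3 `COc1ccc(-c2nn(-c3ccccc3)cc2-c2nc3cc(OC)ccc3[nH]2)cc1` gives 1140 nM

Compound 3 and compound 2 sit together at the low end of these numbers, with a 1.1-fold lower number from compound 2 to compound 3 (0.05 log units; within the scatter), while compound 1 lies well above both, beyond the scatter. The next step leads to compound 4 `COc1ccc(-c2nn(-c3ccccc3)cc2-c2nc3cc(C(=O)OCc4ccccc4)ccc3[nH]2)cc1`, with benzyloxycarbonyl in place of methoxy on an aromatic carbon.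

Among the measured compounds shown here, only one measured single change bears on this: a 1.1-fold lower number from compound 2 to compound 3 (0.05 log units; within the scatter), methoxy in place of chloro on an aromatic carbon. It involves two small groups and says little about a much larger one. Compound 1, at 21300 nM, also carries benzyloxycarbonyl, but it lacks the other methoxy that compound 4 keeps, so it is only a loose guide. It does point towards a higher number, and a step in that direction, beyond the scatter, is expected in this assay. The expected size is a 5.3-fold higher number from compound 3 to compound 4 (0.72 log units; beyond the scatter). For compound 4 the estimated value is 6000 nM, with an expected range of 1500 nM to 24000 nM.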

Compound 4, half-maximal inhibitory concentration: 12400 nM
The estimate for compound 4 lay 2.1-fold (0.32 log units) below the measured number, and the stated range covers the measured number.
By their numbers in this assay, from the lowest: compounds 3 and 2 (each within the scatter of the next); then compounds 4 and 1 (each within the scatter of the next).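

In this assay, this position proves sensitive to the group it carries, which methoxy and chloro alone did not reveal: an 11-fold higher number from compound 3 to compound 4 (1.04 log units; beyond the scatter), and a 9.6-fold higher number from compound 2 to compound 4 (0.98 log units; beyond the scatter). The change of methoxy in place of hydrogen elsewhere on the molecule, made with benzyloxycarbonyl present, gives a 1.7-fold lower number from compound 1 to compound 4 (0.23 log units; within the scatter), so the two compounds carrying benzyloxycarbonyl cannot be told apart in this read-out. No measured finding is at hand to explain the response to benzyloxycarbonyl at this position.

The compounds shown leave open whether the higher number goes with the carbonyl or with the added aromatic ring of the benzyloxycarbonyl group. A carboxylic acid or a methyl ester at this position would help separate those two parts.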